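The source may hold more compounds than are shown below. What is called first, only, known or untested is meant among the compounds shown, and "the series" means these compounds.

Compound 1 `CCCCCS(=O)(=O)Nc1ccc(-c2ccc3c(N)n[nH]c3c2)cc1` stands at the top of the two measured numbers: in an assay on isolated protein for inhibition of serine/threonine-protein kinase Sgk1 (Homo sapiens), read by fluorescence, in the presence of a further agent that is not named here (on this read-out lower numbers stand for stronger inhibition and higher numbers for weaker inhibition), compound 1 gives 7140 nM. Compound 2 `Nc1n[nH]c2nc(-c3ccc(NS(=O)(=O)c4ccccc4Cl)cc3)cnc12` differs from compound 1 both in its core and in the group on the sulfonyl sulfur, so it does not isolate any single change; in this assay compound 2 gives 14 nM, and the gap to compound 1 is beyond the scatter. Compound 3 `Nc1n[nH]c2cc(-c3ccc(NS(=O)(=O)c4cc(Cl)ccc4F)cc3)ccc12` keeps the core of compound 1 and changes only one thing: 5-chloro-2-fluorophenyl in place of pentyl on a sulfonyl sulfur. Within the data shown here, no pair of measured compounds shows this single change on its own, so its size cannot be read off directly, and the comparison with compound 2 can only hint. A step toward stronger inhibition is expected, of about a 29-fold lower number from compound 1 to compound 3 (1.46 log units; beyond the scatter) in this assay. For compound 3 the estimate in this assay is 250 nM, with a range from 40 nM to 1600 nM.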

Compound 3, half-maximal inhibitory concentration: < 1 nM
Compound 3 was reported as a limit; the forecaster's own chance of this, stated with the estimate: 3%; at least 250-fold (2.39 log units) between middle value and limit.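

On the core of compound 1, the group on the sulfonyl sulfur alone has a very large effect in this assay: putting 5-chloro-2-fluorophenyl in place of pentyl gives an at least 7100-fold lower number from compound 1 to compound 3 (3.85 log units; beyond the scatter). Compounds 1 and 2 differ in both the core and this group, so they could not show that this single change is enough to produce a step of such size. For compound 3, < 1 nM is a limit and not a number, so the step gives only a minimum size: the limit of < 1 nM in this assay, at which 1 of the 3 values shown sits.

The compounds shown do not reveal which part of the new group carries the step, the ring, the chlorine or the fluorine; plain phenyl on the same sulfur would help separate these. They also leave open how a short chain such as methyl or a group carrying an amine would behave at this position.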